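Cytotoxicity limits: the aryl change from compound 3 to compound 4

The compounds below may be only part of what the source reports. "The series", "measured", "known", "first", "only" and "open" are said of these compounds alone.

Values in an ADME assay on MT2 cells (Homo sapiens) for cytotoxicity, read by XTT assay, with a stated time of 4 days (on this read-out higher numbers stand for lower toxicity in this test and lower numbers for higher toxicity in this test), so far:
- compound 1 `Cc1nc(C(NC(=O)C(=O)Nc2ccc(Cl)cc2)C2CCCCN2)sc1CO` gives > 108000 nM as a limit
- compound 2 `Cc1nc(C(NC(=O)C(=O)Nc2ccc(F)c(Cl)c2)C2CCCCN2)sc1CO` gives > 77800 nM as a limit
- compound 3 `Cc1ccc(NC(=O)C(=O)NC(c2nc(C)c(CO)s2)C2CCCCN2)c(F)c1` gives > 109000 nM as a limit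

Compound 3 has only the limit > 109000 nM and no number. Compound 1 and compound 2 also stop at limits.

Compound 4 `Cc1nc(C(NC(=O)C(=O)Nc2ccc(Cl)c(F)c2)C2CCCCN2)sc1CO` differs from it as follows: 4-chloro-3-fluorophenyl in place of 2-fluoro-4-methylphenyl on an amide-type nitrogen with 4-chloro-3-fluorophenyl in place of 2-fluoro-4-methylphenyl on an amide-type nitrogen.

Bearing on this are a step that the two limits leave unreadable from compound 1 to compound 3 and a step that the two limits leave unreadable from compound 2 to compound 3 and neither has a readable size. No change of this aryl group has yet given a number, so no step beyond the scatter is expected in this assay and no direction is favoured. The expected step is an at least 1.0-fold lower number from compound 3 to compound 4 (0.03 log units; that floor lies within the scatter) on this reasoning. The estimate for compound 4 is 100000 nM within an expected range from 60000 nM to 150000 nM and probably again as a limit.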

Compound 4, half-maximal cytotoxic concentration: 77800 nM
For compound 4 the middle estimate is 1.3-fold (0.11 log units) above the measured one, within the range that was stated.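

In this assay, among the compounds shown here, compound 4 is the first of the series to give a number rather than a limit, so this aryl position can carry a readable cytotoxic concentration. The change to 4-chloro-3-fluorophenyl gives an at least 1.4-fold lower number from compound 3 to compound 4 (0.14 log units; that floor lies within the scatter) and fluoro in place of hydrogen on an aromatic carbon gives an at least 1.3-fold lower number from compound 1 to compound 4 (0.14 log units; that floor lies within the scatter) as floors within the scatter, so neither shows a real change. 4-Chloro-3-fluorophenyl in place of 3-chloro-4-fluorophenyl gives a number no higher from compound 2 to compound 4 (the limit leaves the size open).

From the compounds shown here alone, the true sizes of these steps remain open. So does the read-out with a methoxy group or a carboxylic acid on this phenyl ring.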